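Chloro on the distal phenyl of compound 2: expected growth inhibition

The source may hold more compounds than are shown below. What is called first, only, known or untested is meant among the compounds shown, and "the series" means these compounds.

Measured in a functional assay on SNB-75 cells (Homo sapiens); a higher number here means a weaker inhibitor of growth, a lower number a stronger inhibitor of growth:
compound 1 `N=C(NO)NS(=O)(=O)c1cc(-c2nnc(-c3ccc(Cl)cc3)s2)c(Cl)cc1SCc1ccccc1`: 1490 nM
compound 2 `COc1cc(CSc2cc(Cl)c(-c3nc(-c4ccccc4)no3)cc2S(=O)(=O)NC(=N)NO)cc(OC)c1OC`: 3980 nM
compound 3 `N=C(NO)NS(=O)(=O)c1cc(-c2nc(-c3ccccc3)no2)c(Cl)cc1SCc1ccccc1`: 1220 nM

Compound 2 gives the highest number of the three; the nearest, compound 1, lies beyond the scatter, and compound 3 lies furthest, also beyond the scatter. For the measured compounds named here, the one single-point step known is a 3.3-fold lower number from compound 2 to compound 3 (0.51 log units; beyond the scatter), which concerns the group on the sulfur-bound chain carbon, not the change considered here.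

Compound 4 `COc1cc(CSc2cc(Cl)c(-c3nc(-c4ccc(Cl)cc4)no3)cc2S(=O)(=O)NC(=N)NO)cc(OC)c1OC` differs from compound 2 by chloro in place of hydrogen on an aromatic carbon. Going by the values given here, no step in the set isolates this change. Compound 1 and compound 3 differ in the chloro as well as in the five-membered ring, and their two values lie within the scatter of each other, so no clear effect of chloro is visible. Compound 4 is therefore expected to stand near compound 2, with a 1.1-fold lower number from compound 2 to compound 4 (0.06 log units; within the scatter) not beyond the scatter, at an estimated 3500 nM (range 1500 nM to 8000 nM).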

Compound 4, concentration for 50% growth inhibition: 2950 nM
Estimate against measurement, compound 4: 1.2-fold (0.07 log units) above; the measured number falls inside the stated range.
By their numbers in this assay, from the lowest: compounds 3, 1, 4 and 2 (each within the scatter of the next, the first and the last beyond it).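

In this assay, 4-chlorophenyl in place of phenyl on the 1,2,4-oxadiazol-5-yl group gives a 1.3-fold lower number from compound 2 to compound 4 (0.13 log units; within the scatter). For the compounds shown here, this is the first direct reading of chloro at this position, and, with 3,4,5-trimethoxyphenyl on the sulfur-bound chain carbon, its effect cannot be told from the scatter. No available data explain this result.

As far as these compounds go, whether chloro reads the same with phenyl on that chain carbon, as in compound 3, remains open. Also open, from the compounds shown here alone, is whether an amine or a carboxylic acid at this position would move the number beyond the scatter.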